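The source may report more compounds than this note shows. Statements on the series, on what has been measured and on what is new or still open speak of the compounds shown alone.

In a functional assay on A549 cells (Homo sapiens) for cytotoxicity, read by MTT assay, with a stated time of 4 days (on this read-out higher numbers stand for weaker inhibition and lower numbers for stronger inhibition), compound 1 `CCC(=O)Nc1ccc(C[C@H]2C(=O)OC[C@@H]2Cc2ccc(OC)c(OC)c2)cc1OC` sits at > 50000 nM as a limit of the assay and not a number. Compound 2 `COc1cc(C[C@H]2C(=O)OC[C@@H]2Cc2ccc(OC)c(OC)c2)ccc1Nc1ccccc1` sits at > 50000 nM as a limit too and has no exact value. It stands at the limit of > 50000 nM in this assay, at which 2 of the 3 values shown sit, with compound 1. Compound 3 `COc1cc(C[C@H]2C(=O)OC[C@@H]2Cc2ccc(OC)c(OC)c2)ccc1Nc1ccc([N+](=O)[O-])cc1` gives a real measurement of 22100 nM.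

Compound 4 `COc1cc(C[C@H]2C(=O)OC[C@@H]2Cc2ccc(OC)c(OC)c2)ccc1Nc1ccc(F)cc1` alters compound 2 in one place: fluoro in place of hydrogen on an aromatic carbon puts fluoro in place of hydrogen on an aromatic carbon. The closest guide is nitro in place of hydrogen, which gave an at least 2.2-fold lower number from compound 2 to compound 3 (0.35 log units; beyond the scatter) for that swap. The other route shows an at least 2.2-fold lower number from compound 1 to compound 3 (0.35 log units; beyond the scatter). Separately, a step that the two limits leave unreadable from compound 1 to compound 2 tells nothing about size. With a single comparable swap and a different group, only a modest lowering is expected, and the estimated move is an at least 1.4-fold lower number from compound 2 to compound 4 (0.15 log units; that floor lies within the scatter) with the limit possibly still in the way. Compound 4 is estimated at 35000 nM with an expected range from 15000 nM to 70000 nM on this evidence.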

Compound 4, half-maximal inhibitory concentration: > 50000 nM
Compound 4: only a limit was reported (the forecaster's own chance of this, stated with the estimate: 55%); at least 1.4-fold (0.15 log units) between middle value and limit.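

Fluoro in place of nitro gives an at least 2.2-fold higher number from compound 3 to compound 4 (0.35 log units; beyond the scatter) in this assay, so the group at this ring carbon, para to a large group, can change the read-out, and the result for nitro does not carry over to fluoro. Compound 4 gives > 50000 nM, which is a limit of the assay and not a number. The steps to compound 4 from compound 1 and from compound 2 cannot be read, and this limit is now the most common result: the limit of > 50000 nM in this assay, at which 3 of the 4 values shown sit.

On these data alone, whether fluoro changes the read-out at all compared with hydrogen stays open. As far as these compounds go, it is also open how an amine or a carboxylic acid at this ring carbon would compare with nitro.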